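Replacing Thiophene with Tolyl on the Cinnamamide Arm

A few compounds are considered here, and "the series" means these few. Any claim that something is new, unique, unknown or untested is made for them only; others in the source may bear on it.

Three measured compounds share one core and differ only in the aryl group on a double-bonded chain carbon bound to a double-bonded chain carbon. In a functional assay on B16-F10 cells (Mus musculus) for inhibition, read by MTT assay, with a stated time of 48 h (on this read-out higher numbers stand for weaker inhibition and lower numbers for stronger inhibition), compound 1 `O=C(/C=C/c1ccccc1Br)Nc1ccc2ncnc(Nc3cccc(Cl)c3)c2c1` gives 1.65 ug/mL and compound 2 `COc1cccc(/C=C/C(=O)Nc2ccc3ncnc(Nc4cccc(Cl)c4)c3c2)c1` gives 1.05 ug/mL; the step of a 1.6-fold lower number from compound 1 to compound 2 (0.20 log units; within the scatter) is small. Compound 3 `O=C(/C=C/c1cccs1)Nc1ccc2ncnc(Nc3cccc(Cl)c3)c2c1` gives 4.26 ug/mL, the highest number of the three, and it stands beyond the scatter from both of the others.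

Compound 4 `Cc1ccc(/C=C/C(=O)Nc2ccc3ncnc(Nc4cccc(Cl)c4)c3c2)cc1` is the unmeasured member: 4-methylphenyl in place of thiophen-2-yl on a double-bonded chain carbon bound to a double-bonded chain carbon. Going by the values given here, two measured steps bear on this change, both of them ending at the thiophene: a 2.6-fold higher number from compound 1 to compound 3 (0.41 log units; beyond the scatter) and a 4.1-fold higher number from compound 2 to compound 3 (0.61 log units; beyond the scatter). In each case a six-membered carbon-only ring gave the lower number and the thiophen-2-yl the higher one, by a modest margin. A 4-methylphenyl is again a six-membered carbon-only ring, so the step back from the thiophene is expected to run in the opposite direction, toward lower numbers, and to be modest in size.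

Compound 4 is therefore estimated at 1.3 ug/mL, between 0.6 ug/mL and 3 ug/mL, which means an expected step of a 3.3-fold lower number from compound 3 to compound 4 (0.52 log units; beyond the scatter).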

Compound 4, half-maximal inhibitory concentration: 2.02 ug/mL
Compound 4: middle estimate off by 1.6-fold (0.19 log units), on the low side; measured number inside the range.
By their numbers in this assay, from the lowest: compounds 2, 1 and 4 (each within the scatter of the next); then compound 3.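

In this assay, going by these compounds alone, a third six-membered carbon-only ring now stands against the thiophen-2-yl, and the step of a 2.1-fold lower number from compound 3 to compound 4 (0.32 log units; beyond the scatter) runs the same way as the two earlier comparisons with compound 1 and compound 2, modest in size but beyond the scatter. The steps of a 1.9-fold higher number from compound 2 to compound 4 (0.28 log units; within the scatter) and a 1.2-fold higher number from compound 1 to compound 4 (0.09 log units; within the scatter) both lie within the scatter, so 4-methylphenyl, 3-methoxyphenyl and 2-bromophenyl cannot be told apart at this place, and among these four compounds only the thiophen-2-yl of compound 3 stands apart from the rest. Nothing available here accounts for that separation.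

The compounds shown leave open whether the gap goes with the five-membered ring or with its sulfur, a question on which a furan-2-yl or a pyridin-2-yl at this place would bear. They also leave open how an amine or a carboxylic acid on the six-membered ring, or a longer chain carrying that ring, would read in this assay on this same core.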